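The source may hold more compounds than are shown below. What is called first, only, known or untested is meant among the compounds shown, and "the series" means these compounds.

Measured so far:
compound 1 `COc1ccc(/C=C/c2ccc3ccccc3c2)cc1`: > 5000 nM
compound 2 `COc1cc(/C=C/c2cn(C(C)=O)c3ccccc23)cc(OC)c1OC`: > 5000 nM

In a functional assay on A549 cells (Homo sapiens) for inhibition (a higher number here means a weaker inhibitor, a lower number a stronger inhibitor), compound 2 gives > 5000 nM, which is a limit of the assay and not a number. The same holds for compound 1: the limit of > 5000 nM in this assay, at which 2 of the 2 values shown sit. Among the compounds with values here, no two measured compounds differ in a single place, so no measured step is available. Compound 3 `COc1cc(/C=C\c2cn(C(C)=O)c3ccccc23)cc(OC)c1OC` has not been measured yet; it differs from compound 2 in one respect: the two compounds have the same atoms and bonds and differ only in configuration as drawn: 1 of 1 stereo elements differ; a double bond is drawn E in compound 2 and Z in compound 3. Starting from a limit, the expected step of an at least 12-fold lower number from compound 2 to compound 3 (1.09 log units; beyond the scatter) points toward stronger inhibition, beyond the usual scatter. Compound 3 is therefore estimated at 400 nM, in the range 30 nM to 5000 nM.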

Compound 3, half-maximal inhibitory concentration: 2850 nM
For compound 3 the middle estimate is 7.1-fold (0.85 log units) below the measured one, within the range that was stated.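

In this assay, compound 3 is the first of the compounds shown to give a number and not a limit, so this double bond is a place where a change can be seen in the read-out. Redrawing the double bond from E to Z gives an at least 1.7-fold lower number from compound 2 to compound 3 (0.24 log units; that floor lies within the scatter). Only this floor is known, and the true size of the step stays open because compound 2 sits at a limit: the limit of > 5000 nM in this assay, at which 2 of the 3 values shown sit.

Whether the Z double bond would give a similar step on a different core is not shown. Also open, from the compounds shown here alone, is what an amine or a carboxylic acid on the shared core would do to the number.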